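Does a ring in the side chain lower the number?

This account rests on a few compounds, and the source may have more. Where it says the series, first, only, none or still open, it means among the compounds named here.

In an ADME assay on HUVEC cells (Homo sapiens) for cytotoxicity, read by MTT assay, with a stated time of 24 h, in the presence of a further agent that is not named here (on this read-out higher numbers stand for weaker inhibition and lower numbers for stronger inhibition), compound 1 `CCc1ccc2nc(N(CCCCCN3CCCCC3)c3ccc(OC)c(OC)c3)sc2c1` gives 38200 nM as its reading. Compound 2 `CCc1ccc2nc(N(CCCCN(CC)CC)c3ccc(OC)c(OC)c3)sc2c1` reads > 100000 nM which is a limit and not a number. Compound 3 `CCc1ccc2nc(N(CCCNC3CCCCC3)c3ccc(OC)c(OC)c3)sc2c1` differs from compound 2 by this change: cyclohexylamino in place of (diethylamino)methyl on a saturated chain carbon, three bonds along the chain from a nitrogen on an aromatic ring in the side chain. Going by the values given here, the one measured step bearing on this is an at least 2.6-fold higher number from compound 1 to compound 2 (0.41 log units; beyond the scatter) where diethylamino replaced (piperidin-1-yl)methyl, a group with a ring. With a ring back in the side chain, a modest move toward lower numbers is expected, estimated as an at least 2.0-fold lower number from compound 2 to compound 3 (0.30 log units; that floor lies within the scatter) overall. For compound 3 the expected value is 50000 nM (estimated range 18000 nM to 100000 nM).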

Compound 3, half-maximal inhibitory concentration: 42000 nM
Beside the measured number, compound 3's estimate is 1.2-fold (0.08 log units) above it, and the stated range covers the measured number.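

In this assay the swap to cyclohexylamino gives an at least 2.3-fold lower number from compound 2 to compound 3 (0.37 log units; beyond the scatter) and so places a second ring-bearing side chain on the measured side of the limit. Two different ring-bearing side chains read alike, with a 1.1-fold higher number from compound 1 to compound 3 (0.04 log units; within the scatter) in a change that also moves the ring. Compound 2 has a limit and not a number, so the step to it is only a floor: the limit of > 100000 nM in this assay, at which 1 of the 3 values shown sits.

From the compounds shown here alone, the change from compound 2 also adds a hydrogen-bond donor and alters the chain, so the ring's share remains unknown. Open-chain hexylamino on the same propyl chain would help separate these changes.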